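The source may report more compounds than this note shows. Statements on the series, on what has been measured and on what is new or still open speak of the compounds shown alone.

The measured compounds in an assay on HEK293 cells for positive allosteric modulation of metabotropic glutamate receptor 2 (Rattus norvegicus), read by thallium flux, with a stated time of 2.5 min (on this read-out higher numbers stand for an effect only at larger amounts of compound and lower numbers for an effect already at smaller amounts), are three. Compound 1, `Cc1c(OCCCCOc2ccc(C(=O)CC(C)(C)C)c(O)c2C)cccc1C(=O)O`, gives 136 nM. Compound 2, `COc1cc(C(=O)O)ccc1OCCCCOc1ccc(C(=O)CC(C)(C)C)c(O)c1C`, gives 47 nM. Compound 3, `CC(=O)c1ccc(OCCCCOc2cccc(C(=O)O)c2C)c(C)c1O`, gives 200 nM.

Compound 3 arises from compound 1 by one change, (hydrogen in place of tert-butyl on a saturated chain carbon bound to a carbonyl carbon). That change made a 1.5-fold higher number from compound 1 to compound 3 (0.17 log units; within the scatter), so the two compounds cannot be told apart on this read-out. Compound 2 has the lowest number of the three; how its core differs from the core of compound 1 is not broken down here, and the gap between them is beyond the scatter.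

Compound 4, `COc1cc(C(=O)O)ccc1OCCCCOc1ccc(C(C)=O)c(O)c1C`, has not yet been measured. For the measured compounds named here, it arises from compound 2 by hydrogen in place of tert-butyl on a saturated chain carbon bound to a carbonyl carbon, the same change at the same place as the one from compound 1 to compound 3. Resting on that earlier step alone, the step from compound 2 to compound 4 is expected to be a 1.5-fold higher number from compound 2 to compound 4 (0.17 log units; within the scatter), of about the same small size. Compound 4 is therefore estimated at 70 nM in this assay, with the likely range running from 35 nM to 140 nM.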

Compound 4, half-maximal effective concentration: 161 nM
Compound 4: middle estimate off by 2.3-fold (0.36 log units), on the low side; the measured number lies above the stated range.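

In this assay, hydrogen in place of tert-butyl on a saturated chain carbon bound to a carbonyl carbon gives a 3.4-fold higher number from compound 2 to compound 4 (0.53 log units; beyond the scatter), a step that on its own lies beyond the scatter. Set beside the earlier step on the core of compound 1, the two steps cannot be told apart: the same change on two cores in this assay, a 1.5-fold higher number (0.17 log units; within the scatter) from compound 1 to compound 3 and a 3.4-fold higher number (0.53 log units; beyond the scatter) from compound 2 to compound 4, 2.3-fold (0.37 log units) apart, within the scatter of two such steps. For the compounds shown here, the change can therefore be read as carrying over between these two cores as a step of similar size, but this rests on only two pairs, so it neither shows that the size would hold on a further core nor rules out that the core of compound 2 responds more strongly.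

Going by these compounds, only tert-butyl and hydrogen appear at this place, so what an ethyl group, an isopropyl group or a phenyl ring would do there remains open. The carboxylic acid is present in all four compounds, which leaves open how an amide or a tetrazole in its stead would read out.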